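This account rests on a few compounds, and the source may have more. Where it says the series, first, only, none or still open, it means among the compounds named here.

Measured in an assay for binding affinity to Alpha-1B adrenergic receptor (Homo sapiens); on this read-out lower numbers stand for stronger inhibition and higher numbers for weaker inhibition:
compound 1 `O=c1c2ccccc2c(Cc2ccc(Cl)cc2)nn1C1CCCN(Cc2ccc(OCCCN3CCCCCC3)cc2)CC1`, 126 nM
compound 2 `CN1CCC[C@@H]1Cn1nc(Cc2cccc(Cl)c2)c2ccccc2c1=O`, 631 nM
compound 3 `CN1CCCCC(n2nc(Cc3ccc(Cl)cc3)c3ccccc3c2=O)C1`, 158 nM

Compound 2 stands at the highest of the three numbers in this assay; compound 3 and compound 1 both sit at lower numbers, and both gaps lie beyond the scatter. Compound 4 `CN1CCC[C@@H]1Cn1nc(Cc2cccc(F)c2)c2ccccc2c1=O` differs from compound 2 in one place: fluoro in place of chloro on an aromatic carbon. Among the measured compounds shown here, no pair of measured compounds shows this exchange, so its size here is not known from the series. The expectation for compound 4 is a modest step from compound 2 toward a higher number, possibly not beyond the scatter, written as a 1.6-fold higher number from compound 2 to compound 4 (0.20 log units; within the scatter). The estimate for compound 4 in this assay is 1000 nM, with a range from 350 nM to 3000 nM.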

Compound 4, inhibition constant: 398 nM
Beside the measured number, compound 4's estimate is 2.5-fold (0.40 log units) above it; the range from low to high includes it.
By their numbers in this assay, from the lowest: compounds 1 and 3 (each within the scatter of the next); then compounds 4 and 2 (each within the scatter of the next).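

In this assay fluoro in place of chloro on an aromatic carbon gives a 1.6-fold lower number from compound 2 to compound 4 (0.20 log units; within the scatter). Among the compounds shown here, this is the first exchange that can be read in one place: on this carbon, meta to a large group, chloro and fluoro cannot be told apart on this read-out. Nothing at hand gives a reason for this result. Open, on these data alone, is whether a nitrile, a methoxy group or an amine on the same carbon would stay as close to compound 2. Also open, as far as these compounds go, is whether the exchange behaves alike in the 4-chlorobenzyl compounds, compound 1 and compound 3.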